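The source may hold more compounds than are shown below. What is called first, only, known or untested is meant among the compounds shown, and "the series" means these compounds.

Measured so far:
compound 1 `COc1ccc2c(c1)CCCC2NC(=O)CCCN1CCN(c2ccccc2OC)CC1` — 186 nM
compound 2 `COc1ccccc1N1CCN(CCCCC(=O)NC2CCCc3cccc(OC)c32)CC1` — 64 nM
compound 3 `COc1ccc2oc(N3CCN(CCCCCC(=O)NC4CCCc5ccccc54)CC3)nc2c1` — 704 nM

In an assay on HEK293 cells for displacement of a labelled ligand from 5-hydroxytryptamine receptor 7 (Rattus norvegicus) (a lower number here means a stronger inhibitor, a higher number a weaker inhibitor), compound 3 gives the highest number of the three. Compound 1 lies nearest to it, while compound 2 lies furthest away with the lowest number of the set. Compound 4 `COc1cccc(N2CCN(CCCCCC(=O)NC3CCCc4ccccc43)CC2)c1` has not yet been measured in this assay. It differs from compound 3 in one place: 3-methoxyphenyl in place of 5-methoxy-1,3-benzoxazol-2-yl on an amine nitrogen in a ring. Going by the values given here, no measured pair shows this exchange directly, so the expected size of the step rests only on the spread of the three measured values. The author expects the step from compound 3 to compound 4 to be a 4.7-fold lower number from compound 3 to compound 4 (0.67 log units; beyond the scatter), toward a lower number and beyond the scatter. Compound 4 is therefore estimated at 150 nM, within a range from 40 nM to 600 nM.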

Compound 4, inhibition constant: 119 nM
Compound 4: middle estimate off by 1.3-fold (0.10 log units), on the high side, and the stated range covers the measured number.
By their numbers in this assay, from the lowest: compounds 2, 4 and 1 (each within the scatter of the next, the first and the last beyond it); then compound 3.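

In this assay, 3-methoxyphenyl in place of 5-methoxy-1,3-benzoxazol-2-yl on an amine nitrogen in a ring gives a 5.9-fold lower number from compound 3 to compound 4 (0.77 log units; beyond the scatter). Going by these compounds alone, this is the first comparison with the rest of the molecule held constant, and it shows that this position affects the number, with the group holding fewer heavy atoms and fewer hydrogen-bond acceptors giving the lower value. Nothing available explains the change. Going by these compounds, it remains open how much of the step depends on the methoxy group, which a plain phenyl or 3-chlorophenyl at this position would test. On these data alone, it is also open whether the exchange holds with a shorter chain.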